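Methoxy to bromo: a step from compound 3

A few compounds are considered here, and "the series" means these few. Any claim that something is new, unique, unknown or untested is made for them only; others in the source may bear on it.

In a functional assay on DU-145 cells (Homo sapiens) for inhibition, read by trypan blue exclusion, with a stated time of 96 h (on this read-out lower numbers stand for stronger inhibition of growth and higher numbers for weaker inhibition of growth), compound 1 `COc1cc(/C=C(/Sc2ccc(Br)cc2)C(=O)c2ccc(Br)cc2)ccc1O` gives 1000 nM, compound 2 `O=C(/C(=C\c1c[nH]c2ccccc12)Sc1ccc(Br)cc1)c1ccc(Br)cc1` gives 1000 nM, and compound 3 `COc1ccc(S/C(=C/c2ccc(Cl)cc2Cl)C(=O)c2ccc(Br)cc2)cc1` gives 1000 nM, so compound 3 stands level with the other two. Compound 4 `O=C(/C(=C\c1ccc(Cl)cc1Cl)Sc1ccc(Br)cc1)c1ccc(Br)cc1` differs from compound 3 in one place: bromo in place of methoxy on an aromatic carbon. This puts bromo in place of methoxy on an aromatic carbon, para to a large group. Among the compounds with values here, the only measured step shows no change at the digits printed from compound 1 to compound 2 (within the scatter), and it concerns another part of the molecule, so it offers only loose guidance. No shift beyond the scatter is therefore expected in this assay. The expected size of the change is no change at the digits printed from compound 3 to compound 4 (within the scatter). For compound 4 the estimated value is 1000 nM, with an expected range from 450 nM to 2200 nM.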

Compound 4, concentration for 50% growth inhibition: 1000 nM
Compound 4: middle estimate and measured number agree at the digits printed, and the stated range covers the measured number.
By their numbers in this assay, from the lowest: compounds 1, 2, 3 and 4 (each within the scatter of the next).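

Bromo in place of methoxy gives no change at the digits printed from compound 3 to compound 4 (within the scatter) in this assay and so leaves the number unmoved at this position on the (4-methoxyphenyl)sulfanyl part. With the bromo in place, 2,4-dichlorophenyl on the double-bonded chain carbon also shows no change at the digits printed from compound 2 to compound 4 (within the scatter) against 1H-indol-3-yl and no change at the digits printed from compound 1 to compound 4 (within the scatter) against 4-hydroxy-3-methoxyphenyl in that same spot. Nothing available explains why these numbers stay level.

As far as these compounds go, whether an amine or a carboxylic acid at the bromo position would shift growth inhibition remains open.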